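Tert-butoxycarbonyl on the ring nitrogen of compound 2

This account rests on a few compounds, and the source may have more. Where it says the series, first, only, none or still open, it means among the compounds named here.

In an ADME assay on HepG2 cells (Homo sapiens) for cytotoxicity (a lower number here means that less compound is tolerated, a higher number that more compound is tolerated), compound 2 (`Fc1cccc(COc2ccc(Nc3ncnc4cc(C#CCN5CCNCC5)sc34)cc2Cl)c1`) gives > 29 uM, which is a limit of the assay and not a number. Its close relative compound 1 (`CN1CCN(CC#Cc2cc3ncnc(Nc4ccc(OCc5cccc(F)c5)c(Cl)c4)c3s2)CC1`), with methyl on the same amine nitrogen in a ring, gives 11 uM.

Compound 3 (`CC(C)(C)OC(=O)N1CCN(CC#Cc2cc3ncnc(Nc4ccc(OCc5cccc(F)c5)c(Cl)c4)c3s2)CC1`) carries tert-butoxycarbonyl in place of hydrogen on that nitrogen: tert-butoxycarbonyl in place of hydrogen on an amine nitrogen in a ring.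

For the measured compounds named here, only one measured step touches this nitrogen. It is an at least 2.6-fold higher number from compound 1 to compound 2 (0.42 log units; beyond the scatter), with hydrogen in place of methyl, and it lies beyond the scatter. Read in reverse, this step links a group on the nitrogen with a lower number, so a group here may again bring the number down. Tert-butoxycarbonyl is far larger than methyl, however, and a single step is a thin guide.

A modest fall in this assay is therefore expected, an estimated at least 1.6-fold lower number from compound 2 to compound 3 (0.20 log units; that floor lies within the scatter). The assay may again report only a limit. For compound 3 the estimated value is 18 uM, with an expected range from 7 uM to 45 uM.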

Compound 3, half-maximal toxic concentration: > 24 uM
Compound 3: only a limit was reported (the forecaster's own chance of this, stated with the estimate: 35%); middle value at least 1.3-fold (0.12 log units) away from the limit.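

Set against methyl on this ring nitrogen, tert-butoxycarbonyl goes with more compound tolerated in this assay: the comparison gives an at least 2.1-fold higher number from compound 1 to compound 3 (0.33 log units; beyond the scatter). Compound 1, with methyl, therefore has a lower number than both compounds it is compared with here, so the earlier idea that any group on this nitrogen brings the number down does not hold as a general reading, and compound 3 is the compound that goes against it. The step from compound 2 to compound 3 cannot be read, and what compound 3 gives is a limit of the assay and not a number: the limit of > 24 uM in this assay, at which 1 of the 3 values shown sits.

From the compounds shown here alone, what compound 2 gives is likewise only a limit of the assay: the limit of > 29 uM in this assay, at which 1 of the 3 values shown sits. How far the true numbers of these two compounds lie past their limits stays open, as does whether a group of a size between methyl and tert-butoxycarbonyl on this nitrogen, such as ethyl or acetyl, would stay with methyl at the lower number or join the other two.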